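This account rests on a few compounds, and the source may have more. Where it says the series, first, only, none or still open, it means among the compounds named here.

Measured so far:
compound 1, `O=C(O)COc1ccc(Cl)cc1C#Cc1ccc(CO)cc1F`: 28 nM in an assay on CHO cells for displacement of a labelled ligand from prostaglandin D2 receptor 2 (Homo sapiens), read by scintillation counting; on this read-out lower numbers stand for stronger inhibition and higher numbers for weaker inhibition
compound 2, `CN(C)C(=O)c1ccc(C#Cc2cc(Cl)ccc2OCC(=O)O)cc1`: 55 nM in this assay

Compound 2 has the higher of the two numbers; its nearest neighbour is compound 1, and the gap between the two values lies within the scatter. The next compound, compound 3 `CS(=O)(=O)c1ccc(C#Cc2cc(Cl)ccc2OCC(=O)O)cc1`, differs from compound 2 in one place: methylsulfonyl in place of dimethylcarbamoyl on an aromatic carbon. Among the compounds with values here, no step between measured compounds is available to guide the expectation, so only a small change is expected in this assay, if any beyond the scatter. For compound 3 the estimate is 40 nM, with a range of 15 nM to 120 nM. The expected step is a 1.4-fold lower number from compound 2 to compound 3 (0.14 log units; within the scatter).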

Compound 3, inhibition constant: 86 nM
Compound 3: middle estimate off by 2.2-fold (0.33 log units), on the low side; the range from low to high includes it.
By their numbers in this assay, from the lowest: compounds 1, 2 and 3 (each within the scatter of the next, the first and the last beyond it).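

In this assay, methylsulfonyl in place of dimethylcarbamoyl on this aromatic carbon, para to a large group, gives a 1.6-fold higher number from compound 2 to compound 3 (0.19 log units; within the scatter), so the two groups cannot be told apart here. The position carries either group without a step beyond the scatter, although the groups differ in their atoms and methylsulfonyl has the additional hydrogen-bond acceptor. Nothing measured here speaks to the reason for this.

Still open, as far as these compounds go, is how an amine or a carboxylic acid on this carbon would read, and whether any group here gives a step beyond the scatter.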